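The source may report more compounds than this note shows. Statements on the series, on what has been measured and on what is new or still open speak of the compounds shown alone.

Measured so far in a functional assay on SK-MEL-2 cells (Homo sapiens) for cytotoxicity, read by sulforhodamine B assay, with a stated time of 48 h, tested at 10 uM; a lower number here means a stronger effect, a higher number a weaker effect of the compound at the concentration tested:
compound 1 `COc1cc(-c2cc(/C=C/C(=O)c3ccc(N)cc3)[nH]n2)cc(OC)c1OC` gives -15%.
compound 2 `COc1ccc(-c2cc(/C=C/C(=O)c3ccc(N)cc3)[nH]n2)cc1OC` gives 46%.
compound 3 `COc1cc(C(=O)/C=C/c2cc(-c3cc(OC)c(OC)c(OC)c3)n[nH]2)cc(OC)c1OC` gives -63%.

One counted step joins two of these. From compound 1 to compound 2 the change is hydrogen in place of methoxy on an aromatic carbon and the effect in this assay is a number 61 percentage points higher from compound 1 to compound 2 (beyond the scatter). Compound 3 stands lowest of the three numbers; how its core differs from the core of compound 1 is not broken down here, so only the two values themselves can be compared.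

Compound 4 `COc1ccc(-c2cc(/C=C/C(=O)c3cc(OC)c(OC)c(OC)c3)[nH]n2)cc1OC` is still to be measured in this assay. From compound 3 it differs by hydrogen in place of methoxy on an aromatic carbon, which is the same change as from compound 1 to compound 2. For compound 4 a step of a number 61 percentage points higher from compound 3 to compound 4 (beyond the scatter) is therefore expected, resting on the earlier step of a number 61 percentage points higher from compound 1 to compound 2 (beyond the scatter). Compound 4 is estimated at -2%, with the range -32% to 28%.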

Compound 4, a percentage reported as activity, at one concentration (the size of the read-out at that concentration, not a potency): -12%
Beside the measured number, compound 4's estimate is 10 percentage points above it, and the stated range covers the measured number.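

In this assay, hydrogen in place of methoxy on an aromatic carbon again weakens the effect, with a number 51 percentage points higher from compound 3 to compound 4 (beyond the scatter). The step carries over from one core to the other at a similar size: the same change on two cores in this assay, a number 61 percentage points higher (beyond the scatter) from compound 1 to compound 2 and a number 51 percentage points higher (beyond the scatter) from compound 3 to compound 4, 10 percentage points apart, within the scatter of two such steps. Going by these compounds alone, this rests on only two pairs and a single change read at one concentration, so it does not show that the step would hold on other cores, at other places on the ring, or at other concentrations.

The compounds shown leave open how a hydroxy group, a fluorine atom or a longer alkoxy chain in place of the methoxy would read in this assay. They also leave open whether removing a further methoxy would add a step of similar size.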